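The compounds below may be only part of what the source reports. "The series", "measured", "known", "first", "only" and "open" are said of these compounds alone.

Compound 1 (`O=c1nc(NO)cc[nH]1`) gives > 100000 nM in a functional assay on NCI-H460 cells (Homo sapiens) for inhibition, read by MTT assay, with a stated time of 72 h (on this read-out lower numbers stand for stronger inhibition and higher numbers for weaker inhibition), a limit of the assay rather than a number. Compound 2 (`NCC(=O)Nc1c[nH]c(=O)[nH]c1=O`) gives > 100000 nM in this assay, again only a limit.

So compound 2 stands at the limit of > 100000 nM in this assay, at which 2 of the 2 values shown sit, and no measured step between two compounds can be drawn from these readings. Compound 3 (`O=C(CCl)Nc1c[nH]c(=O)[nH]c1=O`) differs from compound 2 by chloro in place of amino on a saturated chain carbon bound to a carbonyl carbon. Within the data shown here, with no measured step to lean on, the expected move in this assay is a modest one toward stronger inhibition, an at least 2.5-fold lower number from compound 2 to compound 3 (0.39 log units; beyond the scatter), while another limit remains quite possible. Compound 3 is estimated at 40000 nM, within a range from 5000 nM to 150000 nM.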

Compound 3, half-maximal inhibitory concentration: 14000 nM
Compound 3: middle estimate off by 2.9-fold (0.46 log units), on the high side, within the range that was stated.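

A first measured number now appears in this assay: replacing amino with chloro on the saturated chain carbon bound to a carbonyl carbon gives an at least 7.1-fold lower number from compound 2 to compound 3 (0.85 log units; beyond the scatter). Among these compounds, this position can therefore change the read-out, which the earlier compounds did not show. The true size of the step remains unknown, because the reading for compound 2 is only a limit: the limit of > 100000 nM in this assay, at which 2 of the 3 values shown sit.

As far as these compounds go, whether chlorine specifically is needed remains open. Bromo, hydroxyl or a longer chain at this place would show how much the result depends on chloro itself.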